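Removing the hydroxymethyl from a brominated diaryl ether

The source may report more compounds than this note shows. Statements on the series, on what has been measured and on what is new or still open speak of the compounds shown alone.

Measured compounds:
compound 1 `COc1ccccc1N1CCN(CCCCCOc2c(Br)cc(Br)cc2Oc2ccc(Br)cc2Br)CC1` with 32.2 ug/mL
compound 2 `OCCOc1c(Br)cc(Br)cc1Oc1ccc(Br)cc1Br` with 28.2 ug/mL

In a functional assay on HL-60 cells (Homo sapiens) for cytotoxicity, read by MTT assay, with a stated time of 24 h (a higher number here means a weaker inhibitor, a lower number a stronger inhibitor), compound 1 gives 32.2 ug/mL and compound 2 gives 28.2 ug/mL; the two numbers lie within the scatter of each other, so neither stands apart. Compound 3 `COc1c(Br)cc(Br)cc1Oc1ccc(Br)cc1Br` has not been tested. It differs from compound 2 by hydrogen in place of hydroxymethyl on a saturated chain carbon bound to an oxygen on an aromatic ring. For the measured compounds named here, no measured pair shows the effect of such a change here, so only a small step is expected, no larger than the scatter, in either direction. The step from compound 2 to compound 3 is estimated as a 1.1-fold higher number from compound 2 to compound 3 (0.03 log units; within the scatter). Compound 3 is expected to give 30 ug/mL, within a range from 14 ug/mL to 65 ug/mL.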

Compound 3, half-maximal inhibitory concentration: 28.2 ug/mL
The estimate for compound 3 lay 1.1-fold (0.03 log units) above the measured number; the measured number falls inside the stated range.
By their numbers in this assay, from the lowest: compounds 2, 3 and 1 (each within the scatter of the next).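

In this assay, putting hydrogen in place of the hydroxymethyl gives no change at the digits printed from compound 2 to compound 3 (within the scatter). For the compounds shown here, this is the first direct reading of a single change at this place: the 2-hydroxyethoxy can be cut to methoxy, losing one hydrogen-bond donor and one hydrogen-bond acceptor, without the number shifting beyond the scatter. No measurement shown here offers an explanation for this result.

Still open, going by these compounds, is whether a carboxylic acid or a primary amine in place of the hydroxymethyl would leave the number equally unmoved. On these data alone, a single change at any other place on the shared core also remains untested in these compounds.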